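The source may hold more compounds than are shown below. What is called first, only, known or untested is meant among the compounds shown, and "the series" means these compounds.

Working notes on a small series of aminothiophene ketones. Compound 1 `Nc1scc(-c2cccc(Cl)c2)c1C(=O)c1ccccc1`, compound 2 `Nc1scc(-c2ccc(Cl)cc2)c1C(=O)c1ccccc1` and compound 3 `Nc1scc(-c2cccc(Cl)c2)c1C(=O)c1ccc(Cl)cc1` have been run in a functional assay on CHO cells for agonist activity at adenosine receptor A1 (Homo sapiens), read by fluorescence and ERK phosphorylation, with stated times of 30 min and 1.5 h, tested at 10 uM; a higher number here means a stronger effect of the compound at the concentration tested, a lower number a weaker effect. Compound 1 gives 52% in this assay, compound 2 gives 51%, and compound 3 gives 75%. The step of a number 1 percentage points lower from compound 1 to compound 2 (within the scatter) accompanies the change (4-chlorophenyl in place of 3-chlorophenyl on an aromatic carbon). The core of compound 3 differs from the core of compound 1 by chloro in place of hydrogen on an aromatic carbon, and this goes with the step of a number 23 percentage points higher from compound 1 to compound 3 (beyond the scatter).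

Compound 4 `Nc1scc(-c2ccc(Cl)cc2)c1C(=O)c1ccc(Cl)cc1` remains to be measured. It differs from compound 3 by 4-chlorophenyl in place of 3-chlorophenyl on an aromatic carbon, the same kind of change as that from compound 1 to compound 2, though the surroundings differ: in compound 3 the ring atom next to the place bears a group of 9 heavy atoms, in compound 1 a group of 8 heavy atoms. Resting on the earlier step of a number 1 percentage points lower from compound 1 to compound 2 (within the scatter), which stayed within the scatter, the step expected here is a number 1 percentage points lower from compound 3 to compound 4 (within the scatter). Compound 4 is accordingly expected to give about 74%, estimated between 60% and 88%.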

Compound 4, a percentage reported as activity, at one concentration (the size of the read-out at that concentration, not a potency): 50%
Compound 4: middle estimate off by 24 percentage points, on the high side, outside the stated range (below it).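

In this assay, 4-chlorophenyl in place of 3-chlorophenyl gives a number 25 percentage points lower from compound 3 to compound 4 (beyond the scatter), so this change does not carry unaltered from the core of compound 1 to the core of compound 3: the same change on two cores in this assay, a number 1 percentage points lower (within the scatter) from compound 1 to compound 2 and a number 25 percentage points lower (beyond the scatter) from compound 3 to compound 4, 24 percentage points apart, beyond the scatter of two such steps

Read the other way, chloro in place of hydrogen on an aromatic carbon gives a number 1 percentage points lower from compound 2 to compound 4 (within the scatter), so the gain seen with that change on the core of compound 1 does not carry to the core of compound 2: the same change on two cores in this assay, a number 23 percentage points higher (beyond the scatter) from compound 1 to compound 3 and a number 1 percentage points lower (within the scatter) from compound 2 to compound 4, 24 percentage points apart, beyond the scatter of two such steps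

Both gaps rest on the same four compounds and are one observation seen from two sides: the two changes are not independent in this series, but these data do not show what lies behind this or how either change would behave on any further core.

Apart from the amino group, the only substituent shown is chloro, so it stays open whether the same dependence would hold with fluoro, methoxy or a nitrile in its place. All the read-outs come from one concentration, so they show only a stronger or weaker effect at that concentration and leave open how the four compounds would compare at any other.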